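A few compounds are considered here, and "the series" means these few. Any claim that something is new, unique, unknown or untested is made for them only; others in the source may bear on it.

Measured compounds:
- compound 1, `CCc1ccc(-c2nc3c(c(C)nn3-c3ccccc3)c(-c3ccccc3O)c2C#N)cc1`: 3100 nM
- compound 2, `CCc1ccc(-c2nc3c(c(C)nn3-c3ccccc3)c(-c3ccccc3Cl)c2C#N)cc1`: 1700 nM

In a physicochemical assay for solubility, read by spectrophotometry, in phosphate buffer, with a stated time of 18 h, at pH 7.4 (a higher number here means a more soluble compound, a lower number a less soluble compound), compound 1 gives 3100 nM, and compound 2 gives 1700 nM. Going by the values given here, the two figures lie within the scatter of each other, the only measured step being a 1.8-fold lower number from compound 1 to compound 2 (0.26 log units; within the scatter). Compound 1 therefore stands with a figure that cannot be told apart from that of compound 2.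

The unmeasured compound 3, `CCCc1ccc(-c2nc3c(c(C)nn3-c3ccccc3)c(-c3ccccc3O)c2C#N)cc1`, differs from compound 1 by methyl in place of hydrogen on a saturated chain carbon, two bonds along the chain from an aromatic carbon. Among the compounds with values here, no measured step concerns a change of this kind: the single step in hand, a 1.8-fold lower number from compound 1 to compound 2 (0.26 log units; within the scatter), swaps one group for another on an aromatic carbon and says nothing about lengthening a saturated chain. The expectation for compound 3 in this assay can therefore rest only on the size of the change itself, which adds one carbon without ring, donors, acceptors or charge. A small step, or none beyond the scatter, is expected, with the estimated step being a 1.6-fold lower number from compound 1 to compound 3 (0.19 log units; within the scatter). Compound 3 is thus estimated at 2000 nM, with a range from 800 nM to 4500 nM.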

Compound 3, solubility: 6500 nM
Beside the measured number, compound 3's estimate is 3.3-fold (0.51 log units) below it; measured number outside the range, above it.
By their numbers in this assay, from the lowest: compounds 2 and 1 (each within the scatter of the next); then compound 3.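

In this assay the change from 4-ethylphenyl to 4-propylphenyl gives a 2.1-fold higher number from compound 1 to compound 3 (0.32 log units; beyond the scatter) and so counts as a modest step, yet it shows that this saturated chain position is not silent: one added methyl, with no ring, hydrogen-bond donor, acceptor or charge, moves the number upward beyond the scatter. The earlier swap of hydroxy for chloro on an aromatic carbon, a 1.8-fold lower number from compound 1 to compound 2 (0.26 log units; within the scatter) and thus within the scatter, gave no such clear movement and said nothing about the chain. The data offer no measured explanation for the rise, so it stands as an observation only.

A single step cannot show whether the number would keep rising with a longer chain such as butyl, or how a branched chain such as isopropyl, or a chain carrying an amine or a carboxylic acid, would behave. It also leaves open whether the same lengthening would give a similar step in compound 2, which carries chloro in place of hydroxy.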